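From 3-methylazetidin-1-yl to 3-hydroxy-3-methylazetidin-1-yl

The compounds below may be only part of what the source reports. "The series", "measured", "known", "first", "only" and "open" are said of these compounds alone.

In a physicochemical assay for solubility, measured as kinetic solubility (a higher number here means a more soluble compound, a lower number a less soluble compound), compound 1 (`Cc1cnc(NC(=O)c2cc(Oc3cnc(C(=O)N(C)C)cn3)c3cc(C)oc3c2)cn1`) gives 176000 nM and compound 2 (`Cc1cnc(NC(=O)c2cc(Oc3ccc(S(C)(=O)=O)cc3)c3cc(C)oc3c2)cn1`) gives 3000 nM on the same read-out. Compound 3 (`Cc1cc2c(Oc3cnc(C(=O)N4CC(C)C4)cn3)cc(C(=O)Nc3cnccn3)cc2o1`) stands at 49000 nM as second of the three, under compound 1 and over compound 2, with both gaps beyond the scatter. Compound 4 (`Cc1cc2c(Oc3cnc(C(=O)N4CC(C)(O)C4)cn3)cc(C(=O)Nc3cnccn3)cc2o1`) differs from compound 3 by hydroxy in place of hydrogen on a saturated ring carbon with hydroxy in place of hydrogen on a saturated ring carbon. Among the compounds with values here, no measured pair isolates this change, so the expectation rests on the structural change alone. In this assay the estimated step of a 1.8-fold higher number from compound 3 to compound 4 (0.26 log units; within the scatter) is expected to be upward and modest, possibly not far beyond the scatter. For compound 4 the expected value is 90000 nM within an estimated range of 40000 nM to 200000 nM for now.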

Compound 4, solubility: 137000 nM
For compound 4 the middle estimate is 1.5-fold (0.18 log units) below the measured one; the measured number falls inside the stated range.
By their numbers in this assay, from the lowest: compound 2; then compound 3; then compounds 4 and 1 (each within the scatter of the next).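

In this assay, within the data shown here, the step of a 2.8-fold higher number from compound 3 to compound 4 (0.45 log units; beyond the scatter) is the first in this set to isolate a single change, hydroxy in place of hydrogen on a saturated ring carbon of the four-membered ring. It shows that this position responds to that change by more than the scatter. On these data alone, whether an amine or a methoxy group on the same ring carbon would give a step of similar size stays open, as does whether the hydroxy step holds on another core. No supporting data bear on the reason for this step.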